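Swapping a hydroxymethyl pyrimidine for an amino methyl pyrimidine

The compounds below may be only part of what the source reports. "The series", "measured", "known", "first", "only" and "open" are said of these compounds alone.

Of the compounds shown here, three sharing one core have been tested in a functional assay (aorta) with Oryctolagus cuniculus as the target; on this read-out higher numbers stand for weaker inhibition and lower numbers for stronger inhibition. Compound 1 `Fc1ccccc1Cn1nc(-c2ccccn2)c2cccnc21` gives 4800 nM. Among the compounds with values here, compound 2 `OCc1ccnc(-c2nn(Cc3ccccc3F)c3ncccc23)n1` gives 1300 nM, the lowest of the two clear numbers, and the step of a 3.7-fold lower number from compound 1 to compound 2 (0.57 log units; beyond the scatter) is the only single-point change measured so far. Compound 3 `Nc1ccnc(-c2nn(Cc3ccccc3F)c3ncccc23)n1` gives 270 nM; 265000 nM (2 entries), two entries so far apart that they leave no single number to compare with.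

Compound 4 `Cc1cc(N)nc(-c2nn(Cc3ccccc3F)c3ncccc23)n1` has not yet been tested. It differs from compound 2 in one place: 4-amino-6-methylpyrimidin-2-yl in place of 4-(hydroxymethyl)pyrimidin-2-yl on an aromatic carbon. Within the data shown here, no measured step covers this exact change. Among the measured compounds shown here, the one measured step, from compound 1 to compound 2, exchanged a pyridin-2-yl for a 4-(hydroxymethyl)pyrimidin-2-yl and was modest in size. The nearest relative of compound 4 is compound 3, which carries an amino group on the same ring, and the several entries of compound 3 in this assay, 270 nM; 265000 nM (2 entries) shows that its two readings disagree by a very wide margin, so it offers little firm guidance.

On this basis the expected step of a 2.2-fold lower number from compound 2 to compound 4 (0.34 log units; beyond the scatter) is small and uncertain in direction. For compound 4 the estimate in this assay is 600 nM, with a plausible range from 80 nM to 5000 nM.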

Compound 4, half-maximal inhibitory concentration: 536000 nM
Compound 4: middle estimate off by 890-fold (2.95 log units), on the low side; the whole stated range lies below it.
By their numbers in this assay, from the lowest: compound 2; then compound 1; then compound 4.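

In this assay, a change of 4-(hydroxymethyl)pyrimidin-2-yl to 4-amino-6-methylpyrimidin-2-yl on this aromatic carbon gives a 410-fold higher number from compound 2 to compound 4 (2.62 log units; beyond the scatter), so this position can respond very strongly to what the attached ring carries. The two groups have the same counts of heavy atoms, hydrogen-bond donors and hydrogen-bond acceptors, and neither has a net charge, so these counts alone do not predict the outcome here. The comparison with the simpler group shows a 110-fold higher number from compound 1 to compound 4 (2.05 log units; beyond the scatter), so a pyrimidine ring in place of pyridin-2-yl does not by itself lower the number, and the modest gain seen earlier does not carry over to every substituted pyrimidine.

The compounds shown do not separate the effect of the amino group from that of the methyl group, and the closest comparison, which lacks only the methyl group, gives no single number: the several entries of compound 3 in this assay, 270 nM; 265000 nM (2 entries)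

A pyrimidine carrying only a methyl group, or a carboxylic acid in place of the hydroxymethyl group, would show how much each feature matters at this position.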